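Stereochemical Inversion in a Diterpene Glycoside Sugar Ring

The source may hold more compounds than are shown below. What is called first, only, known or untested is meant among the compounds shown, and "the series" means these compounds.

Measured compounds:
Compound 1 `C=C[C@@](C)(CC[C@H]1C(C)=CC[C@H]2C(C)(C)CCC[C@]12C)O[C@@H]1O[C@H](C)[C@H](O)[C@H](O)[C@H]1O`: 3.5 ug/mL
Compound 2 `C=C[C@@](C)(CC[C@H]1C(C)=CC[C@H]2C(C)(C)CCC[C@]12C)O[C@@H]1O[C@H](C)[C@H](O)[C@H](OC(C)=O)[C@H]1O`: 3.6 ug/mL

Both compounds were tested in a functional assay on A549 cells (Homo sapiens) for cytotoxicity, read by sulforhodamine B assay; a lower number here means that less compound is needed, a higher number that more compound is needed for the effect. Compound 1 stands alongside compound 2 rather than apart from it, since the step of a 1.0-fold higher number from compound 1 to compound 2 (0.01 log units; within the scatter) is within the scatter, so the two numbers cannot be told apart.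

Compound 3 `C=C[C@@](C)(CC[C@H]1C(C)=CC[C@H]2C(C)(C)CCC[C@]12C)O[C@@H]1O[C@@H](C)[C@@H](O)[C@H](O)[C@H]1O` has not yet been measured. Compared with compound 1, (the two compounds have the same atoms and bonds and differ only in configuration as drawn: 2 of 9 stereo elements differ; a stereocentre at a saturated ring carbon is drawn R in compound 1 and S in compound 3; a stereocentre at a saturated ring carbon is drawn R in compound 1 and S in compound 3). Within the data shown here, the only measured step, a 1.0-fold higher number from compound 1 to compound 2 (0.01 log units; within the scatter), concerns an acetyl on an oxygen and not a change of configuration, so it gives no direct guidance on this change; it shows only that the shared core tolerates a small alteration on the sugar without a shift beyond the scatter.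

With no stereochemical comparison available, compound 3 is expected to land near compound 1, an estimated step of a 1.1-fold higher number from compound 1 to compound 3 (0.04 log units; within the scatter), giving an estimated 3.8 ug/mL with a range from 1.5 ug/mL to 10 ug/mL.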

Compound 3, concentration for half-maximal effect: 3.9 ug/mL
Compound 3: middle estimate off by 1.0-fold (0.01 log units), on the low side; low and high end bracket the measured number.
By their numbers in this assay, from the lowest: compounds 1, 2 and 3 (each within the scatter of the next).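

Changing the drawn configuration at two saturated ring carbons of the sugar gives a 1.1-fold higher number from compound 1 to compound 3 (0.05 log units; within the scatter) in this assay, so the two numbers cannot be told apart. Among these compounds, compound 2 tested an added acetyl, whereas compound 3 adds the first evidence on the spatial arrangement of the sugar, and for this pair that arrangement makes no difference that can be resolved in this assay. This pair gives a clean test of configuration, with no added or lost group to confuse the reading: the fact that compounds 1 and 3 differ only in the configuration as drawn.

As far as these compounds go, the two ring carbons changed together here, so the effect of each one alone remains unknown, and the two effects could cancel. From the compounds shown here alone, it also remains open whether the sugar would tolerate a larger change, such as an amine or a carboxylic acid in place of one of its hydroxyl groups.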